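This account rests on a few compounds, and the source may have more. Where it says the series, first, only, none or still open, it means among the compounds named here.

Measured in a functional assay on a cell-free system (plasma, Homo sapiens) for inhibition, with Plasma (Rattus norvegicus) as the target; on this read-out lower numbers stand for stronger inhibition and higher numbers for weaker inhibition:
- compound 1 `Cc1c(OCc2ccccc2)ccc2c(N3CCNCC3)cc(=O)oc12`: 1900 nM
- compound 2 `Cc1c(OCc2cccnc2)ccc2c(N3CCNCC3)cc(=O)oc12`: 980 nM
- compound 3 `COc1c(C)cnc(COc2ccc3c(N4CCNCC4)cc(=O)oc3c2C)c1C`: 3300 nM

Not yet measured: compound 4 `CSCCOc1ccc2c(N3CCNCC3)cc(=O)oc2c1C`.

Compound 1 lies within the scatter of both other compounds, with a 1.9-fold lower number from compound 1 to compound 2 (0.29 log units; within the scatter) and a 1.7-fold higher number from compound 1 to compound 3 (0.24 log units; within the scatter). Only a 3.4-fold higher number from compound 2 to compound 3 (0.53 log units; beyond the scatter) exceeds the scatter. The change to compound 4 is (methylsulfanyl)methyl in place of phenyl on a saturated chain carbon bound to an oxygen on an aromatic ring. Read one bond further out, this is benzyloxy to 2-(methylsulfanyl)ethoxy. All three measured steps exchange one aromatic ring for another, so none shows what happens when the ring is lost. They remain only a loose guide to size, and they give no direction. The expected outcome is a 1.2-fold higher number from compound 1 to compound 4 (0.06 log units; within the scatter), which means no expected change beyond the scatter. For compound 4 the estimated value is 2200 nM, with an expected range of 700 nM to 6500 nM.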

Compound 4, half-maximal inhibitory concentration: 1500 nM
Beside the measured number, compound 4's estimate is 1.5-fold (0.17 log units) above it, within the range that was stated.
By their numbers in this assay, from the lowest: compounds 2, 4, 1 and 3 (each within the scatter of the next, the first and the last beyond it).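

In this assay an aromatic ring is not needed on this saturated chain carbon to stay in this range: with 2-(methylsulfanyl)ethoxy in place of benzyloxy there is a 1.3-fold lower number from compound 1 to compound 4 (0.10 log units; within the scatter), and the exchange for the pyridin-3-yl group gives a 1.5-fold higher number from compound 2 to compound 4 (0.18 log units; within the scatter). Only the exchange for the 4-methoxy-3,5-dimethylpyridin-2-yl group passes the scatter, with a 2.2-fold lower number from compound 3 to compound 4 (0.34 log units; beyond the scatter). No measured evidence bears on the origin of these numbers.

Still open, going by these compounds, is whether the sulfur atom matters, which a plain butoxy chain would test. On these data alone, a terminal amine or carboxylic acid on this chain also remains open.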